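The compounds below may be only part of what the source reports. "The series", "measured", "known", "first", "only" and "open" are said of these compounds alone.

Compounds measured so far:
Compound 1, `Nc1ncnc2c1ncn2[C@@H]1O[C@H](COC(=O)NCc2ccccc2)[C@@H](O)[C@H]1O`: in an assay on COS-7 cells for inhibition of sodium/nucleoside cotransporter 2 (Homo sapiens), read by scintillation counting, in the presence of a further agent that is not named here (a higher number here means a weaker inhibitor, a lower number a stronger inhibitor), compound 1 gives > 100000 nM.
Compound 2, `Nc1ncnc2c1nc(NCc1ccccc1-c1ccccc1)n2[C@@H]1O[C@H](CO)[C@@H](O)[C@H]1O`: in this assay compound 2 gives > 100000 nM.

Compound 1 stands at the limit of > 100000 nM in this assay, at which 2 of the 2 values shown sit, so its value is a limit of the assay and not a number. The value of compound 2 is also a limit, so neither compound offers a number to compare against. Compound 3, `CCCCCC(=O)OC[C@H]1O[C@@H](n2cnc3c(N)ncnc32)[C@H](O)[C@@H]1O`, differs from compound 1 by pentyl in place of benzylamino on a carbonyl carbon. For the measured compounds named here, no step between two measured compounds with numbers is available, so the effect of this change cannot be read from the data. The account therefore expects no step beyond the scatter in this assay, in either direction. Compound 3 is expected to give about 100000 nM in this assay, with a range from 30000 nM to 300000 nM. The step of a number no higher from compound 1 to compound 3 (the limit leaves the size open) implied by this estimate is expected to lie within the scatter, with a limit the most likely outcome.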

Compound 3, half-maximal inhibitory concentration: > 100000 nM
Compound 3 ended at the assay's limit; the forecaster's own chance of this, stated with the estimate: 75%; the middle value sits exactly at the limit.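

No new step can be read: compound 1 and compound 3 both end at a limit and not a number in this assay, so swapping benzylamino for pentyl has no readable size: the limit of > 100000 nM in this assay, at which 3 of the 3 values shown sit.

The compounds shown leave open which change, if any, would give a readable number in this assay.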